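The compounds below may be only part of what the source reports. "The series", "measured", "known", "first", "only" and "open" are said of these compounds alone.

Measured compounds:
Compound 1, `COc1cc(/C=C/C(=O)/C=C(/C=C/c2ccc(O)c(OC)c2)NCCO)ccc1O` — in a functional assay on Caco-2 cells (Homo sapiens) for activation, read by fluorescence, tested at 10 uM (a higher number here means a weaker effect of the compound at the concentration tested, a lower number a stronger effect), compound 1 gives 96.6%.
Compound 2, `O=C(/C=C(/C=C/c1ccc(O)cc1)NCCO)/C=C/c1ccc(O)cc1` — in this assay compound 2 gives 87.1%.
Compound 3, `COCCCNC(=C\C(=O)/C=C/c1ccc(O)cc1)/C=C/c1ccc(O)cc1` — in this assay compound 3 gives 89%.

Compound 1 has the largest of the three numbers, but its gaps to compound 3 and to compound 2 both lie within the usual scatter, so the three compounds cannot be told apart on these readings. The unmeasured compound 4, `COCCCNC(=C\C(=O)/C=C/c1ccc(O)c(OC)c1)/C=C/c1ccc(O)c(OC)c1`, is reached from compound 1 by a single change: methoxymethyl in place of hydroxy on a saturated chain carbon, two bonds along the chain from an amine nitrogen. The same change has already been made once, on the pair that lacks the methoxy groups on the rings: a number 1.9 percentage points higher from compound 2 to compound 3 (within the scatter). That step fell within the scatter. Within the data shown here, only this one pair bears on the question, so the expectation for compound 4 rests on it alone, and it points to a shift in this assay no larger than the scatter. The step from compound 1 to compound 4 is therefore expected to be a number 0.4 percentage points higher from compound 1 to compound 4 (within the scatter). Compound 4 is estimated to give 97%, with a range from 87% to 106%.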

Compound 4, a percentage reported as activity, at one concentration (the size of the read-out at that concentration, not a potency): 84.8%
Compound 4: middle estimate off by 12.2 percentage points, on the high side, outside the stated range (below it).
By their numbers in this assay, from the lowest: compounds 4, 2, 3 and 1 (each within the scatter of the next, the first and the last beyond it).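

In this assay, replacing (2-hydroxyethyl)amino with (3-methoxypropyl)amino on the core of compound 1 gives a number 11.8 percentage points lower from compound 1 to compound 4 (beyond the scatter). A lower number means a stronger effect at the concentration tested, so this change on a saturated chain carbon, two bonds along the chain from an amine nitrogen, can shift the read-out by more than the scatter, which the earlier pair did not show. This still does not establish that the two cores respond differently to the change: the same change on two cores in this assay, a number 1.9 percentage points higher (within the scatter) from compound 2 to compound 3 and a number 11.8 percentage points lower (beyond the scatter) from compound 1 to compound 4, 13.7 percentage points apart, within the scatter of two such steps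

The change both removes the hydroxy and lengthens the chain, and the compounds shown cannot separate these two differences; a 2-methoxyethyl chain would help to do so. Also open, on these data alone, is how an amine or a carboxylic acid in place of the hydroxy would read.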